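A Bromo Substituent Added to the Core of Compound 1

The compounds below may be only part of what the source reports. "The series", "measured", "known", "first", "only" and "open" are said of these compounds alone.

Three amides sharing one core have been tested in an assay for inhibition of protein kinase C iota type (Homo sapiens), read by mobility shift assay, with a stated time of 60 min; a lower number here means a stronger inhibitor, a higher number a weaker inhibitor. Compound 1 `Nc1nccnc1C(=O)Nc1ccncc1` gives 23000 nM, the lowest of the three numbers. Compound 2 `Nc1nccnc1C(=O)Nc1cccnc1` gives 77000 nM, and compound 3 `Cc1cc(NC(=O)c2nccnc2N)cc(C)n1` gives 263000 nM; both lie beyond the scatter from compound 1, with compound 3 the furthest. Compound 4 `Nc1nccnc1C(=O)Nc1ccnc(Br)c1` has not yet been measured. It differs from compound 1 by bromo in place of hydrogen on an aromatic carbon, next to the ring nitrogen and meta to a large group. For the measured compounds named here, no step between measured compounds shows what a bromo substituent does here, so the size of the change is open. Compound 4 is expected to stay close to compound 1, the step of a 1.5-fold lower number from compound 1 to compound 4 (0.19 log units; within the scatter) being small and probably within the scatter. The estimate for compound 4 in this assay is 15000 nM, in a range from 4000 nM to 60000 nM.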

Compound 4, half-maximal inhibitory concentration: > 384000 nM
Compound 4: only a limit was reported (the forecaster's own chance of this, stated with the estimate: 15%); middle value at least 25-fold (1.40 log units) away from the limit.
By their numbers in this assay, from the lowest: compound 1; then compound 2; then compound 3. At a limit, above all of these: compound 4.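

The position next to the ring nitrogen proves sensitive to this change: bromo in place of hydrogen on an aromatic carbon there gives an at least 16-fold higher number from compound 1 to compound 4 (1.22 log units; beyond the scatter). For the compounds shown here, this is the first single change that can be read on the core of compound 1, and it moves the number well beyond the scatter. For compound 4, only a limit was obtained: the limit of > 384000 nM in this assay, at which 1 of the 4 values shown sits.

Going by these compounds, how far the true value of compound 4 lies past this limit remains open. So does whether fluoro or an amine on the same carbon would keep the number close to that of compound 1.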